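Chlorinated thiophenes on a dihydropyrazole core: cytotoxicity

The source may hold more compounds than are shown below. What is called first, only, known or untested is meant among the compounds shown, and "the series" means these compounds.

Compound 1 `c1cc(C2=NNC(c3ccc(N4CCCCC4)cc3)C2)cs1`: 27000 nM
Compound 2 `Cc1ccsc1C1=NNC(c2ccc(N3CCCCC3)cc2)C1`: 2300 nM
Compound 3 `Clc1ccsc1C1=NNC(c2ccc(N3CCCCC3)cc2)C1`: 10200 nM

Three compounds sharing one core were measured in an ADME assay on CCRF-CEM cells (Homo sapiens) for cytotoxicity, with a stated time of 5 days; on this read-out lower numbers stand for stronger inhibition and higher numbers for weaker inhibition. Compound 3 gives 10200 nM in this assay and stands second highest of the three; compound 1 lies a 2.6-fold lower number from compound 1 to compound 3 (0.42 log units; beyond the scatter) away, and compound 2 is the furthest, a 4.4-fold higher number from compound 2 to compound 3 (0.65 log units; beyond the scatter).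

Compound 4 `Clc1cc(C2=NNC(c3ccc(N4CCCCC4)cc3)C2)c(Cl)s1` has not yet been measured. It differs from compound 3 in one place: 2,5-dichlorothiophen-3-yl in place of 3-chlorothiophen-2-yl on a carbon with a double bond to nitrogen. The group that enters is a thiophen-3-yl carrying two chloro substituents, whereas compound 1 carries the unsubstituted thiophen-3-yl and compound 3 the chloro-bearing thiophen-2-yl.

Among the compounds with values here, two measured steps bear on this change. Moving from the plain thiophen-3-yl to a chlorinated thiophen-2-yl gave a 2.6-fold lower number from compound 1 to compound 3 (0.42 log units; beyond the scatter), a modest gain. Replacing methyl by chloro on the aromatic carbon gave a 4.4-fold higher number from compound 2 to compound 3 (0.65 log units; beyond the scatter), a modest loss. Within the data shown here, neither step copies the present change exactly, and no compound here carries two chloro groups, so the step is expected to stay close to compound 3: the estimated step is a 1.0-fold lower number from compound 3 to compound 4 (0.01 log units; within the scatter), not clearly beyond the scatter in either direction. Compound 4 is therefore expected to give about 10000 nM in this assay, within a range from 3000 nM to 35000 nM.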

Compound 4, half-maximal inhibitory concentration: 37700 nM
Compound 4: the middle estimate sits 3.8-fold (0.58 log units) below what was measured; the measured number lies above the stated range.
By their numbers in this assay, from the lowest: compound 2; then compound 3; then compounds 1 and 4 (each within the scatter of the next).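

In this assay, adding a second chloro group while moving the point of attachment did not extend the gain seen with the chlorinated thiophen-2-yl: replacing 3-chlorothiophen-2-yl with 2,5-dichlorothiophen-3-yl gave a weaker result (a 3.7-fold higher number from compound 3 to compound 4 (0.57 log units; beyond the scatter)), and the gap was larger when measured from the methyl-bearing group (a 16-fold higher number from compound 2 to compound 4 (1.21 log units; beyond the scatter)). The dichlorinated group and the unsubstituted thiophen-3-yl lie within the scatter of each other (a 1.4-fold higher number from compound 1 to compound 4 (0.14 log units; within the scatter)), so among these four compounds the two thiophen-3-yl compounds, compound 1 and compound 4, form one level, while the two thiophen-2-yl compounds, compound 2 and compound 3, both give clearly lower numbers. Nothing available here accounts for these differences.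

The compounds shown leave open whether the attachment point or the chloro substitution matters more, since the thiophen-3-yl appears only unsubstituted or with both chloro groups, and no thiophen-2-yl carries two chloro groups. They also leave open how this position would respond to a thiophene bearing an amine or a carboxylic acid, or to a longer chain in place of the methyl of compound 2.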